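Trifluoromethyl for Fluorine Tried on a Second Core

The compounds below may be only part of what the source reports. "The series", "measured", "known", "first", "only" and "open" are said of these compounds alone.

The measured compounds:
compound 1, `CC(O)(CSc1ccc(F)cc1)C(=O)Nc1ccc(S(F)(F)(F)(F)F)cc1`, 23000 nM
compound 2, `CC(O)(CSc1cccc(C(F)(F)F)c1)C(=O)Nc1ccc(S(F)(F)(F)(F)F)cc1`, 18800 nM
compound 3, `CC(O)(CS(=O)(=O)c1ccc(F)cc1)C(=O)Nc1cccc(S(F)(F)(F)(F)F)c1`, 37900 nM

These are numbers from a functional assay on VCaP cells (Homo sapiens) for antiproliferative activity, read by propidium iodide staining, with a stated time of 96 h; a higher number here means a weaker inhibitor, a lower number a stronger inhibitor. Compound 2 differs from compound 1 by one change, (3-(trifluoromethyl)phenyl in place of 4-fluorophenyl on a sulfur), and the step was a 1.2-fold lower number from compound 1 to compound 2 (0.09 log units; within the scatter). Compound 3 gives 37900 nM in this assay; how its core differs from the core of compound 1 is not broken down here. Compound 4, `CC(O)(CS(=O)(=O)c1cccc(C(F)(F)F)c1)C(=O)Nc1cccc(S(F)(F)(F)(F)F)c1`, carries the same kind of change relative to compound 3, namely (3-(trifluoromethyl)phenyl in place of 4-fluorophenyl on a sulfonyl sulfur); the place differs in that here the sulfur is a sulfonyl sulfur. Because the earlier step was a 1.2-fold lower number from compound 1 to compound 2 (0.09 log units; within the scatter), the step from compound 3 to compound 4 is expected to be similarly small, a 1.3-fold lower number from compound 3 to compound 4 (0.10 log units; within the scatter). Compound 4 is therefore estimated at 30000 nM, between 12000 nM and 80000 nM.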

Compound 4, half-maximal inhibitory concentration: 35500 nM
Compound 4: middle estimate off by 1.2-fold (0.07 log units), on the low side, and the stated range covers the measured number.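

In this assay, placing 3-(trifluoromethyl)phenyl instead of 4-fluorophenyl on the sulfonyl sulfur gave a 1.1-fold lower number from compound 3 to compound 4 (0.03 log units; within the scatter). Set beside the earlier step, the change gives a matching result on the two cores: the same change on two cores in this assay, a 1.2-fold lower number (0.09 log units; within the scatter) from compound 1 to compound 2 and a 1.1-fold lower number (0.03 log units; within the scatter) from compound 3 to compound 4, 1.1-fold (0.06 log units) apart, within the scatter of two such steps. This shows that the change stayed within the scatter on both cores, but not that it helps or harms activity, and two such small steps cannot show how a change that clearly moves the number would carry from one core to another.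

The compounds shown leave open whether an amine or a carboxylic acid in place of the 3-(trifluoromethyl)phenyl would give a step beyond the scatter. Also open, on these data alone, is whether the same change stays this small on any further core.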